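The source may report more compounds than this note shows. Statements on the series, on what has been measured and on what is new or still open speak of the compounds shown alone.

Measured so far:
Compound 1 `COc1cc(C)cc(-c2c(-c3ccnc(-c4ccc(C(C)=O)cc4)c3)cnn2CC#N)c1` — 84%
Compound 2 `COc1cc(C)cc(-c2nn(CC#N)cc2-c2ccnc(-c3ccc(N(C)C)cc3)c2)c1` — 16%

In a functional assay on HOP-62 cells (Homo sapiens) for cytotoxicity, read by sulforhodamine B assay, with a stated time of 48 h, tested at 100 nM (on this read-out higher numbers stand for a weaker effect at the one concentration tested and lower numbers for a stronger effect), compound 1 gives 84%, the higher of the two numbers recorded. Compound 2 is a relative that differs from compound 1 in several places. In this assay compound 2 gives 16%, a value that sits far below that of compound 1 and well beyond the usual scatter. Since the two compounds differ in several places, nothing more than what these two values show can be said of the pair.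

Compound 3 `COc1cc(C)cc(-c2c(-c3ccnc(-c4ccc(N(C)C)cc4)c3)cnn2CC#N)c1` has not yet been measured in this assay. It differs from compound 1 in one place:

dimethylamino in place of acetyl on an aromatic carbon

The dimethylamino group that enters is the same group that compound 2 carries on its corresponding ring. With compound 2 at 16%, a strong effect at the single concentration, the move from compound 1 to compound 3 is expected to lower the number by a large margin, a number 54 percentage points lower from compound 1 to compound 3 (beyond the scatter), well beyond the scatter. Compound 3 is therefore estimated at 30%, within a range from 10% to 60%.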

Compound 3, a percentage reported as activity, at one concentration (the size of the read-out at that concentration, not a potency): 33%
Compound 3: middle estimate off by 3 percentage points, on the low side; low and high end bracket the measured number.
By their numbers in this assay, from the lowest: compound 2; then compound 3; then compound 1.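

In this assay, the exchange of acetyl for dimethylamino on an aromatic carbon, para to a large group, is a large step on its own: a number 51 percentage points lower from compound 1 to compound 3 (beyond the scatter), with nothing else in the structure changing. The earlier pair differed in several places, so it could not tie any change in the number to a single group, whereas this step ties a change beyond the scatter to the move from 4-acetylphenyl to 4-(dimethylamino)phenyl. This position is therefore one where the read-out depends strongly on the group it carries, although nothing measured here accounts for the size of the step.

From the compounds shown here alone, with only acetyl and dimethylamino seen at this position, it remains open how a primary amine, a morpholine ring or a carboxylic acid in the same place would read in this assay. Going by these compounds, it also remains open whether a step of this size would be seen for the same exchange on a different core, since this one comparison rests on a single pair of compounds at a single concentration.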